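Swapping prop-1-yn-1-yl for vinyl on a small compound

The compounds below may be only part of what the source reports. "The series", "measured", "known", "first", "only" and "open" are said of these compounds alone.

Cytotoxicity is followed here through a functional assay on NCI-H522 cells (Homo sapiens) for cytotoxicity, with a stated time of 3 days (a higher number here means a weaker inhibitor, a lower number a stronger inhibitor), and in this test compound 1 `C#Cc1sc(-c2ccc(F)cc2)nc1C(=O)OCC` gives 3530 nM. Compound 2 `CC#Cc1nc(C(=O)OCC)cs1` gives > 40000 nM, which is a limit of the assay and not an exact number. As far as these compounds go, that places compound 2 at the limit (the limit of > 40000 nM in this assay, at which 1 of the 2 values shown sits), so its true value is unknown.

Compound 3 `C=Cc1nc(C(=O)OCC)cs1` is still unmeasured. It carries vinyl in place of prop-1-yn-1-yl on an aromatic carbon. Going by the values given here, no measured pair shows what this kind of swap does in this assay. The expectation therefore rests on compound 2, with its limit of > 40000 nM, as the starting point.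

The expected step of a number no higher from compound 2 to compound 3 (the limit leaves the size open) is none beyond the scatter, with neither direction favoured. For compound 3 the estimated value is 40000 nM, within an expected range from 15000 nM to 80000 nM.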

Compound 3, half-maximal inhibitory concentration: > 40000 nM
Compound 3: no number, only a limit; the forecaster's own chance of this, stated with the estimate: 70%; the middle value sits exactly at the limit.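

In this assay compound 3 gives > 40000 nM, which is a limit of the assay and not a number. Compound 2 stands at the same limit, so no step can be read between compound 2 and compound 3: the limit of > 40000 nM in this assay, at which 2 of the 3 values shown sit.

The compounds shown leave open whether vinyl in place of prop-1-yn-1-yl on an aromatic carbon changes cytotoxicity at all.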